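Amide to Ketone on a Shared Core

The source may hold more compounds than are shown below. What is called first, only, known or untested is meant among the compounds shown, and "the series" means these compounds.

compound 1: `CCCNC(=O)c1sc2nc(-c3cccs3)cc(-c3ccccc3)c2c1N` — > 7500 nM
compound 2: `CCCC[S+]([O-])c1sc2nc(-c3ccccc3)nc(-c3ccccc3)c2c1N` — 4.9 nM

In an assay for inhibition of 15-hydroxyprostaglandin dehydrogenase [NAD(+)] (Homo sapiens), read by fluorescence, with a stated time of 15 min, in the presence of a further agent that is not named here (a higher number here means a weaker inhibitor, a lower number a stronger inhibitor), compound 1 reaches only the limit > 7500 nM, so no number is known for it. This is the limit of > 7500 nM in this assay, at which 1 of the 2 values shown sits. Among the compounds with values here, compound 2 gives 4.9 nM in this assay, but it carries a different core and a different side group, so no single step joins the two. Compound 3 `CCCCC(=O)c1sc2nc(-c3cccs3)cc(-c3ccccc3)c2c1N` differs from compound 1 by butyl in place of propylamino on a carbonyl carbon. Within the data shown here, no measured pair shows what this change does, so the expected step is small and uncertain, most likely none beyond the scatter. The value expected for compound 3 is 6000 nM, between 600 nM and 30000 nM. The step of an at least 1.2-fold lower number from compound 1 to compound 3 (0.09 log units; that floor lies within the scatter) is likewise an estimate only.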

Compound 3, half-maximal inhibitory concentration: > 7500 nM
Compound 3: no number, only a limit; the forecaster's own chance of this, stated with the estimate: 55%; middle value at least 1.2-fold (0.09 log units) away from the limit.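

Compound 1 and compound 3 both stand at a limit and not at a number, so no step between them can be read: the limit of > 7500 nM in this assay, at which 2 of the 3 values shown sit.

As far as these compounds go, what butyl in place of propylamino on a carbonyl carbon does in this assay remains open.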